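A few compounds are considered here, and "the series" means these few. Any claim that something is new, unique, unknown or untested is made for them only; others in the source may bear on it.

Measured compounds:
Compound 1, `Cc1ccc(-n2cc(COc3ccc(/C=C/C(=O)c4cc5c(cc4O)OC(C)(C)CC5)cc3)nn2)cc1Br`: in a functional assay on A549 cells (Homo sapiens) for antiproliferative activity, read by MTT assay (a lower number here means a stronger inhibitor, a higher number a weaker inhibitor), compound 1 gives 125000 nM.
Compound 2, `Cc1ccc(-n2cc(COc3ccc(/C=C/C(=O)c4ccc5c(c4O)CCC(C)(C)O5)cc3)nn2)cc1Br`: in this assay compound 2 gives "not active" (no number reported), with no number given.
Compound 3, `CC1(C)CCc2cc(C(=O)/C=C/c3ccc(OCc4cn(Cc5ccc([N+](=O)[O-])cc5)nn4)cc3)c(O)cc2O1`: in this assay compound 3 gives 35800 nM.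

Compound 1 and compound 2 are built from the same atoms joined differently; the difference between the two cores is not broken down here. Compound 3 carries the core of compound 1 and differs from it in one place, (4-nitrobenzyl in place of 3-bromo-4-methylphenyl on an aromatic nitrogen). That change gives a 3.5-fold lower number from compound 1 to compound 3 (0.54 log units; beyond the scatter), a modest gain that nonetheless exceeds the usual scatter.

The unmeasured compound 4, `CC1(C)CCc2c(ccc(C(=O)/C=C/c3ccc(OCc4cn(Cc5ccc([N+](=O)[O-])cc5)nn4)cc3)c2O)O1`, carries the core of compound 2 and differs from it by 4-nitrobenzyl in place of 3-bromo-4-methylphenyl on an aromatic nitrogen. The two place descriptions match word for word, so this is the same change. Since compound 2 has no number, only a cautious expectation can be formed: the gain seen in a 3.5-fold lower number from compound 1 to compound 3 (0.54 log units; beyond the scatter) on the other core, applied to a compound with no reported activity, suggests compound 4 may also sit at very weak potency or fail to register. The expected value for compound 4 in this assay is 150000 nM, estimated between 40000 nM and 600000 nM.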

Compound 4, half-maximal inhibitory concentration: 69900 nM
For compound 4 the middle estimate is 2.1-fold (0.33 log units) above the measured one; measured number inside the range.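

In this assay, within the data shown here, compound 4 gives 69900 nM, but compound 2 is recorded as not active, without a number, so no step between compound 2 and compound 4 can be read. Going by these compounds, how large the 4-nitrobenzyl change is on the core of compound 2 stays open. No supporting data bear on this result.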